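The compounds below may be only part of what the source reports. "The series", "measured", "known", "first", "only" and "open" are said of these compounds alone.

Compound 2 `NC(=S)Nc1cccc(OCCCCCCCCNC(=S)Nc2cc(Cl)cc(Cl)c2)c1` has been tested in an ADME assay on Huh-7 cells (Homo sapiens) for cytotoxicity (on this read-out higher numbers stand for lower toxicity in this test and lower numbers for higher toxicity in this test), where compound 2 gives 12000 nM. Among the measured compounds shown here, that is the only actual number among the two results available. Compound 1 `NC(=S)Nc1cccc(OCCCCCNC(=S)Nc2cccc3ccccc23)c1` is the other substance tested, and for compound 1 the reading is the limit > 50000 nM, so the assay gives no number for it. This is captured by the limit of > 50000 nM in this assay, at which 1 of the 2 values shown sits. Compound 3 `NC(=S)Nc1cccc(OCCCCCCCCNC(=S)Nc2ccccc2)c1` has not yet been measured. It differs from compound 2 in one place: phenyl in place of 3,5-dichlorophenyl on an amide-type nitrogen. For the measured compounds named here, no pair of measured compounds shows this exact change, so its size cannot be read from the data. The expected step of a 2.1-fold higher number from compound 2 to compound 3 (0.32 log units; beyond the scatter) in this assay is modest and points toward lower toxicity. For compound 3 the estimate in this assay is 25000 nM, with a range from 8000 nM to 60000 nM, and a fair chance that only a limit is reported.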

Compound 3, half-maximal cytotoxic concentration: > 50000 nM
Compound 3: no number, only a limit; the forecaster's own chance of this, stated with the estimate: 35%; at least 2.0-fold (0.30 log units) between middle value and limit.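

Replacing 3,5-dichlorophenyl with phenyl on an amide-type nitrogen gives, in this assay, an at least 4.1-fold higher number from compound 2 to compound 3 (0.61 log units; beyond the scatter). The rest of the molecule is the same in both compounds, so this single change on the ring is enough to move the read-out, and lower toxicity in this test goes with the phenyl form. From the compounds shown here alone, compound 3 gives only a limit, > 50000 nM, so the full size of the step remains unknown.

Going by these compounds, whether a single chlorine, or another group on this ring such as methoxy or trifluoromethyl, would give a measurable number remains open. The compounds also can hardly be ranked against one another, as most of them give no actual number: the limit of > 50000 nM in this assay, at which 2 of the 3 values shown sit.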